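The source may hold more compounds than are shown below. What is called first, only, known or untested is meant among the compounds shown, and "the series" means these compounds.

Compound 1 `CC(=O)Nc1cccc(-c2ccc(C(=O)N(Cc3cccc(OCCCCCC(=O)O)c3)C(C)C)cc2)c1` and compound 2 `CCOC(=O)CCCCCOc1cccc(CN(C(=O)c2ccc(-c3cccc(NC(C)=O)c3)cc2)C(C)C)c1` are joined by a single measured step in an ADME assay on Raji cells (Homo sapiens) for cytotoxicity, read by CellTiter-Glo and resazurin assay, with a stated time of 72 h (a lower number here means that less compound is needed, a higher number that more compound is needed for the effect), namely a step that the two limits leave unreadable from compound 1 to compound 2. In this assay compound 1 gives > 26000 nM, which is a limit of the assay and not a number. In this assay compound 2 gives > 26000 nM, again a limit rather than a number. Among the measured compounds shown here, both values sit at the limit of > 26000 nM in this assay, at which 2 of the 2 values shown sit, so compound 2 stands at that limit and the only step known so far has no readable size or direction. Compound 3 `CCOC(=O)CCCCCOc1cccc(CN(C(=O)c2ccc(-c3ccoc3)cc2)C(C)C)c1` carries furan-3-yl in place of 3-acetamidophenyl on an aromatic carbon. For the measured compounds named here, no measured step involves a change of this kind, and the one step known is itself unreadable, so nothing measured points to a rise or a fall. Compound 3 is therefore expected to give a limit once more, with an estimate of 30000 nM, a range from 10000 nM to 100000 nM and an expected step that the limit leaves unreadable from compound 2 to compound 3.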

Compound 3, half-maximal effective concentration: > 26000 nM
Compound 3 was reported as a limit (the forecaster's own chance of this, stated with the estimate: 80%); the middle value lies beyond the limit too.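

No new step can be read between compound 2 and compound 3, since each gives a limit of the assay and not a number: the limit of > 26000 nM in this assay, at which 3 of the 3 values shown sit.

The compounds shown leave open where any of them would give an actual value in this assay, and how large the changes between them are.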